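Trifluoromethyl for Chloro on the Urea Phenyl

The source may hold more compounds than are shown below. What is called first, only, known or untested is meant among the compounds shown, and "the series" means these compounds.

Compound 1, `Cc1ccc(NC(=O)Nc2cccc(-c3cccc4[nH]nc(N)c34)c2)cc1Cl`, gives 1750 nM in a functional assay on A549 cells (Homo sapiens) for inhibition, read by MTT assay, with a stated time of 48 h; a lower number here means a stronger inhibitor, a higher number a weaker inhibitor.
Compound 2, `Nc1n[nH]c2cccc(-c3cccc(NC(=O)Nc4cccc(Cl)c4)c3)c12`, gives 1720 nM in this assay.

Compound 2 and compound 1 sit at the same level: the step of a 1.0-fold lower number from compound 1 to compound 2 (0.01 log units; within the scatter) is within the scatter, so neither can be called stronger. Compound 3, `Nc1n[nH]c2cccc(-c3cccc(NC(=O)Nc4cccc(C(F)(F)F)c4)c3)c12`, differs from compound 2 by trifluoromethyl in place of chloro on an aromatic carbon. Within the data shown here, no measured step involves this change; the one known step, hydrogen in place of methyl, says nothing about it. A step within the scatter is therefore expected in this assay, in either direction. Compound 3 is estimated at 1500 nM, between 500 nM and 4500 nM, an expected step of a 1.1-fold lower number from compound 2 to compound 3 (0.06 log units; within the scatter).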

Compound 3, half-maximal inhibitory concentration: 1950 nM
Estimate against measurement, compound 3: 1.3-fold (0.11 log units) below, and the stated range covers the measured number.
By their numbers in this assay, from the lowest: compounds 2, 1 and 3 (each within the scatter of the next).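

In this assay the swap of chloro for trifluoromethyl on this ring gives a 1.1-fold higher number from compound 2 to compound 3 (0.05 log units; within the scatter) and so does not shift the number beyond the scatter, even though one heavy atom is replaced by four. Changing the whole group, 3-chloro-4-methylphenyl to 3-(trifluoromethyl)phenyl, gives a 1.1-fold higher number from compound 1 to compound 3 (0.05 log units; within the scatter) and also stays within the scatter. So far, this place on the ring has accepted each of these groups with no readable change.

As far as these compounds go, whether an amine, a carboxylic acid or a longer chain here would hold the number at this level remains open. Nothing available explains why these steps stay so small.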